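The compounds below may be only part of what the source reports. "The series", "measured", "known", "first", "only" and "open" are said of these compounds alone.

Working notes on the series. In a functional assay on SW-620 cells (Homo sapiens) (a lower number here means a stronger inhibitor, a higher number a weaker inhibitor), compound 1 (`COc1cc(NC(C)CCCNC(=O)NOCc2ccccc2)c2ncccc2c1`) gives 20000 nM and compound 2 (`COc1cc(NC(C)CCCNC(=O)NCCNC(=O)NCCCC(C)Nc2cc(OC)cc3cccnc23)c2ncccc2c1`) gives 17000 nM as its value, so the two lie within the scatter of each other and compound 1 has no separate standing on these numbers. Compound 3 (`COc1cc(NC(C)CCCNC(=O)NO)c2ncccc2c1`) has hydrogen in place of benzyl on an oxygen, a benzyloxy to hydroxy change on the oxygen whose other neighbours are amide-type nitrogen, and hydrogen in place of benzyl on an oxygen gives the count. Among the measured compounds shown here, no measured pair isolates this change, so its size in this assay can only be estimated. No step beyond the scatter is expected, and the estimated 1.3-fold lower number from compound 1 to compound 3 (0.12 log units; within the scatter) stays small. Compound 3 is expected at 15000 nM in this estimate, with a range from 5000 nM to 45000 nM around it.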

Compound 3, half-maximal inhibitory concentration: 35000 nM
Beside the measured number, compound 3's estimate is 2.3-fold (0.37 log units) below it; measured number inside the range.
By their numbers in this assay, from the lowest: compounds 2, 1 and 3 (each within the scatter of the next, the first and the last beyond it).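

In this assay, the pair of compounds that differ in one place gives a 1.8-fold higher number from compound 1 to compound 3 (0.24 log units; within the scatter) and this step stays within the scatter. Hydrogen in place of benzyl, on an oxygen whose other neighbours are amide-type nitrogen, therefore produces no readable difference here, so the benzyl and its six-membered aromatic ring of carbon only are not shown to matter for this read-out. No supporting measurement bears on this result.

Still open, from the compounds shown here alone, is whether another group on this oxygen, such as methyl or a longer chain like phenylethyl, would give a step beyond the scatter. Also open, going by these compounds, is whether replacing the whole hydroxyamino end with a carboxylic acid or an amine would move the number on the shared core.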